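The source may report more compounds than this note shows. Statements on the series, on what has been measured and on what is new or still open speak of the compounds shown alone.

Compound 1 `COc1ccc(CCCN2CCC(COCc3ccccn3)CC2)cc1`: 5900 nM
Compound 2 `COc1ccc(CCCN2CCC(CCC(c3ccccc3)c3ccccc3)CC2)cc1`: 200 nM
Compound 3 `COc1ccccc1CCCN1CCC(COC(c2ccccc2)c2ccccc2)CC1`: 2400 nM

All three values come from a functional assay on cells (T-cell line, Homo sapiens) for inhibition; on this read-out lower numbers stand for stronger inhibition and higher numbers for weaker inhibition. With compound 3 at 2400 nM, this compound holds the middle place among the three. Compound 1 reads higher and compound 2 reads lower, both beyond the scatter, and the gap to compound 2 is the wider one.

The next compound to be measured is compound 4 `CCCCCCN1CCC(COC(c2ccccc2)c2ccccc2)CC1`. Its change from compound 3 is propyl in place of 2-methoxyphenyl on a saturated chain carbon, three bonds along the chain from an amine nitrogen in a ring.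

Going by the values given here, no two measured compounds differ in one place, so the series gives no direct measure of this change. Among the compounds with values here, no measured compound lacks an aromatic ring at the end of the chain on the amine nitrogen, so compound 4 also moves outside the measured set. The starting point for the expectation is compound 3 at 2400 nM, and a modest loss of inhibition seems the likelier direction. The expected step, towards a higher number, is a 1.7-fold higher number from compound 3 to compound 4 (0.22 log units; within the scatter). The range is kept wide for that reason. For compound 4 the estimated value is 4000 nM, with an expected range of 1200 nM to 13000 nM.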

Compound 4, half-maximal inhibitory concentration: 5500 nM
The estimate for compound 4 lay 1.4-fold (0.14 log units) below the measured number; the measured number falls inside the stated range.
By their numbers in this assay, from the lowest: compound 2; then compound 3; then compounds 4 and 1 (each within the scatter of the next).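

In this assay, going by these compounds alone, putting propyl in place of 2-methoxyphenyl on a saturated chain carbon, three bonds along the chain from an amine nitrogen in a ring, gives a 2.3-fold higher number from compound 3 to compound 4 (0.36 log units; beyond the scatter) and supplies the first direct reading of a single change. The loss lies beyond the scatter but remains modest: compound 4 still gives 5500 nM with no aromatic ring at the end of the chain, so in this pair inhibition on the shared core does not depend on that ring being present. No measurement at hand explains why this change has this effect.

This single pair removes the ring and the methoxy group together, so the contribution of each remains unresolved; an unsubstituted phenyl at this place would separate them, and a longer alkyl chain or a cyclohexyl group would show whether the size of the replacement matters. Going by these compounds, whether the same change has a similar effect on the core of compound 2 also remains open, as that core has no matched partner here.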